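This account rests on a few compounds, and the source may have more. Where it says the series, first, only, none or still open, it means among the compounds named here.

Measured so far in a functional assay on MCF7 cells (Homo sapiens) for cytotoxicity, read by MTT assay, with a stated time of 96 h; on this read-out higher numbers stand for weaker inhibition and lower numbers for stronger inhibition:
- Compound 1 `COc1cc(C(=O)c2cn(-c3ccccc3)cc2-c2ccccc2Cl)cc(OC)c1OC`: 76 nM
- Compound 2 `COc1cc(C(=O)c2cn(-c3ccccc3)cc2-c2ccc([N+](=O)[O-])cc2)cc(OC)c1OC`: 590 nM
- Compound 3 `COc1cc(C(=O)c2cn(-c3ccccc3)cc2/C=C/c2ccccc2)cc(OC)c1OC`: 2200 nM

Compound 2 sits in the middle of this small set. Its number is the second highest of the three, with compound 3 as its nearest neighbour and compound 1 furthest away. The next compound, compound 4 `COc1cc(C(=O)c2cn(-c3ccc(C)cc3)cc2-c2ccc([N+](=O)[O-])cc2)cc(OC)c1OC`, differs from compound 2 in one place: methyl in place of hydrogen on an aromatic carbon. This puts methyl in place of hydrogen on an aromatic carbon, so that phenyl becomes 4-methylphenyl.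

Three measured steps offer some guidance: a 7.8-fold higher number from compound 1 to compound 2 (0.89 log units; beyond the scatter), a 3.7-fold higher number from compound 2 to compound 3 (0.57 log units; beyond the scatter) and a 29-fold higher number from compound 1 to compound 3 (1.46 log units; beyond the scatter). Each of them swaps a different group on the shared core and leaves the phenyl untouched. They show that numbers in this assay can move clearly within this set, but none of them measures a change on the phenyl itself. The data therefore give no direction for the new methyl, and a swap of one whole group for another is a poor guide to its size. No step beyond the scatter is expected, although a real shift either way remains possible. The expected step is a 1.2-fold lower number from compound 2 to compound 4 (0.07 log units; within the scatter). For compound 4 the estimated value is 500 nM, with an expected range of 170 nM to 1500 nM.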

Compound 4, half-maximal inhibitory concentration: 200 nM
The estimate for compound 4 lay 2.5-fold (0.40 log units) above the measured number; the range from low to high includes it.
By their numbers in this assay, from the lowest: compound 1; then compound 4; then compound 2; then compound 3.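

In this assay, within the data shown here, the added methyl that turns phenyl into 4-methylphenyl gives a 3.0-fold lower number from compound 2 to compound 4 (0.47 log units; beyond the scatter), and this is the first measured change on that phenyl. The step shows that this position is not a silent one: a single added carbon, placed para to a large group, is enough to move the number beyond the usual scatter, and here it moves towards stronger inhibition. Nothing presented here explains why this small addition has that effect, so the result stands as an observation and not as a mechanism.

This single pair cannot show whether the methyl has the same effect when the rest of the molecule differs, as with the 2-chlorophenyl group of compound 1 or the 2-phenylethenyl group of compound 3. The compounds shown also leave open whether the trend goes further or reverses with an ethyl group, a methoxy group or a chlorine atom at the same place, so one methyl defines a single point and not a trend.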